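This account rests on a few compounds, and the source may have more. Where it says the series, first, only, none or still open, it means among the compounds named here.

Three compounds share a common theme: compound 1 `Cc1ccc2c(=O)[nH]c(-c3ccccc3C)nc2c1`, compound 2 `Cc1ccc2nc(-c3ccccc3C)[nH]c(=O)c2c1` and compound 3 `Cc1ccc2c(=O)[nH]c(-c3ccccc3F)nc2c1`. In a functional assay on HCT-15 cells (Homo sapiens) for cytotoxicity, read by MTT assay, with a stated time of 2 days (on this read-out lower numbers stand for stronger inhibition and higher numbers for weaker inhibition), compound 1 gives 11900 nM, compound 2 gives 11700 nM and compound 3 gives 10300 nM. Compound 2 and compound 1 are built from the same atoms joined differently; the difference between the two cores is not broken down here, and their two values lie within the scatter of each other. Compound 3 differs from compound 1 by fluoro in place of methyl on an aromatic carbon, a step of a 1.2-fold lower number from compound 1 to compound 3 (0.06 log units; within the scatter). Compound 4 `Cc1ccc2nc(-c3ccccc3F)[nH]c(=O)c2c1` is not yet measured; it differs from compound 2 by fluoro in place of methyl on an aromatic carbon, the same change. For compound 4 the step in this assay is expected to be a 1.2-fold lower number from compound 2 to compound 4 (0.07 log units; within the scatter), because the same change gave a 1.2-fold lower number from compound 1 to compound 3 (0.06 log units; within the scatter). Compound 4 is thus estimated at 10000 nM, between 5000 nM and 20000 nM.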

Compound 4, half-maximal inhibitory concentration: > 50000 nM
Compound 4 was reported as a limit (the forecaster's own chance of this, stated with the estimate: 5%); middle value at least 5.0-fold (0.69 log units) away from the limit.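

In this assay compound 4 gives > 50000 nM, which is a limit of the assay and not a number. On the core of compound 2, fluoro in place of methyl gives a step of an at least 4.2-fold higher number from compound 2 to compound 4 (0.63 log units; beyond the scatter), so the change did not behave alike on the two cores: the same change on two cores in this assay, a 1.2-fold lower number (0.06 log units; within the scatter) from compound 1 to compound 3 and an at least 4.2-fold higher number (0.63 log units; beyond the scatter) from compound 2 to compound 4, at least 4.9-fold (0.69 log units) apart, beyond the scatter of two such steps This shows that a step seen on one core could not be carried over to the other in these two pairs, but it does not show why, and the full size of the new step stays unknown.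

The compounds shown leave open how chloro, methoxy or an amine on the same aromatic carbon would behave on each core. They also leave open whether any other change would differ between the two cores in the same way.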